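Adding One Chlorine: Expecting Little Change

The source may report more compounds than this note shows. Statements on the series, on what has been measured and on what is new or still open speak of the compounds shown alone.

Compound 1 `CC(C)n1nc2c(c1-c1ccccc1)CCNCC2`: 530 nM
Compound 2 `c1ccc(-c2c3c(nn2C2CC2)CCNCC3)cc1`: 600 nM

In an ADME assay on membranes from Cortex for displacement of a labelled ligand from Adrenergic receptor alpha-1 (Rattus norvegicus), read by radioligand binding, with a stated time of 60 min (on this read-out higher numbers stand for weaker inhibition and lower numbers for stronger inhibition), compound 1 gives 530 nM, the lower of the two numbers, while compound 2 gives 600 nM. For the measured compounds named here, the only measured step, a 1.1-fold higher number from compound 1 to compound 2 (0.05 log units; within the scatter), lies within the scatter and concerns a different part of the molecule. Compound 3 `CC(C)n1nc2c(c1-c1ccc(Cl)cc1)CCNCC2` differs from compound 1 by chloro in place of hydrogen on an aromatic carbon. Going by the values given here, no measured step bears on this change, so no shift beyond the scatter is expected. For compound 3 the estimate is a step of a 1.2-fold lower number from compound 1 to compound 3 (0.07 log units; within the scatter), giving an expected value of 450 nM, within the range 150 nM to 1400 nM.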

Compound 3, inhibition constant: 20 nM
Beside the measured number, compound 3's estimate is 23-fold (1.35 log units) above it, outside the stated range (below it).
By their numbers in this assay, from the lowest: compound 3; then compounds 1 and 2 (each within the scatter of the next).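

In this assay, chloro in place of hydrogen on an aromatic carbon, para to a large group, gives a 27-fold lower number from compound 1 to compound 3 (1.42 log units; beyond the scatter). For the compounds shown here, the earlier step on the aromatic nitrogen stayed within the scatter, so this is the first sign that the number responds strongly to a change in the shared core, here from a single added heavy atom. No measurement shown gives a reason for the size of this step. Open, on these data alone, is whether fluoro, methoxy or an amine at this carbon would move the number as far. Also open, as far as these compounds go, is whether chloro would give a similar step on compound 2.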